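A few compounds are considered here, and "the series" means these few. Any claim that something is new, unique, unknown or untested is made for them only; others in the source may bear on it.

Measured so far:
compound 1 `O=C1CC(c2ccccc2F)C(=O)N1CN1CCN(c2ccccc2)CC1` gives 300 mg/kg;
compound 2 `O=C1CC(c2ccccc2F)C(=O)N1CN1CCN(c2ccc(F)cc2)CC1` gives 30 mg/kg;
compound 3 `O=C1CC(c2ccccc2F)C(=O)N1CN1CCN(c2cccc(C(F)(F)F)c2)CC1` gives 100 mg/kg.

All three were tested in a functional assay on the whole organism (strain CF-1 albino) with Mus musculus as the target, with a stated time of 4 h; on this read-out lower numbers stand for an effect already at smaller amounts and higher numbers for an effect only at larger amounts of compound. Compound 2 stands lowest of the three numbers: the step of a 10-fold lower number from compound 1 to compound 2 (1.00 log units; beyond the scatter) and the step of a 3.3-fold higher number from compound 2 to compound 3 (0.52 log units; beyond the scatter) both lie beyond the scatter, as does a 3.0-fold lower number from compound 1 to compound 3 (0.48 log units; beyond the scatter). Compound 4 `O=C1CC(c2ccccc2Br)C(=O)N1CN1CCN(c2ccc(F)cc2)CC1` differs from compound 2 by bromo in place of fluoro on an aromatic carbon. Going by the values given here, none of the measured steps bears on this change: each of them alters the group on an amine nitrogen in a ring, whereas compound 4 is altered on an aromatic carbon of a six-membered aromatic ring of carbon only, ortho to a large group. With nothing to lean on, no step beyond the scatter is expected in this assay, in either direction. Compound 4 is therefore estimated at 30 mg/kg, within a range from 10 mg/kg to 100 mg/kg. This estimate corresponds to an expected step of no change at the digits printed from compound 2 to compound 4 (within the scatter).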

Compound 4, minimum effective dose: 100 mg/kg
The estimate for compound 4 lay 3.3-fold (0.52 log units) below the measured number; the measured number falls inside the stated range.
By their numbers in this assay, from the lowest: compound 2; then compounds 3 and 4 (each within the scatter of the next); then compound 1.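

Compound 4 is the first change shown on the 2-fluorophenyl side rather than on the amine nitrogen in a ring. In this assay, the step of a 3.3-fold higher number from compound 2 to compound 4 (0.52 log units; beyond the scatter) shows that this aromatic carbon is not indifferent to the group it carries, with fluoro giving the lower number of the two. No measurement available here accounts for this step.

Open, as far as these compounds go, is how chloro, methoxy or plain hydrogen at this place would read. Also open, from the compounds shown here alone, is whether the bromo step holds with phenyl or 3-(trifluoromethyl)phenyl on the amine nitrogen.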